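The compounds below may be only part of what the source reports. "The series", "measured", "known", "first", "only" and "open" are said of these compounds alone.

Measured compounds:
- compound 1, `COc1ccccc1Nc1nc(SCc2cn(Cc3ccccc3Cl)nn2)nc(-c2ccccc2)c1C#N`, in a functional assay on ECa-109 cells (Homo sapiens) for inhibition, read by MTT assay, with a stated time of 72 h (a higher number here means a weaker inhibitor, a lower number a stronger inhibitor), compound 1 gives 9670 nM
- compound 2, `Cc1ccccc1Nc1nc(SCc2cn(Cc3ccccc3Cl)nn2)nc(-c2ccccc2)c1C#N`, in this assay compound 2 gives 9740 nM

Compound 2 stands with the highest of the two numbers shown, but its nearest neighbour is compound 1, and the step of a 1.0-fold higher number from compound 1 to compound 2 (0.00 log units; within the scatter) lies within the scatter, so the two compounds cannot be told apart on these numbers.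

Compound 3 is `N#Cc1c(Nc2ccccc2)nc(SCc2cn(Cc3ccccc3Cl)nn2)nc1-c1ccccc1`. Compared with compound 2, the change is hydrogen in place of methyl on an aromatic carbon. For the measured compounds named here, the only measured step that bears on this position is the one from compound 1 to compound 2, a methyl in place of methoxy on the same aromatic carbon, and it was a 1.0-fold higher number from compound 1 to compound 2 (0.00 log units; within the scatter). Two different substituents at this place gave the same number, which is taken as a sign that the group there is not decisive in this assay. Compound 3 is therefore expected to show no step beyond the scatter, with an estimated step of a 1.0-fold lower number from compound 2 to compound 3 (0.01 log units; within the scatter).

Compound 3 is estimated at 9500 nM, within a range from 4000 nM to 25000 nM.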

Compound 3, half-maximal inhibitory concentration: > 64000 nM
Compound 3: only a limit was reported; the forecaster's own chance of this, stated with the estimate: 10%; at least 6.7-fold (0.82 log units) between middle value and limit.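

The earlier pair showed only that methoxy and methyl could not be told apart at this place, whereas removing the group altogether has a clear effect in this assay: the change from 2-methylphenyl to phenyl gives an at least 6.5-fold higher number from compound 2 to compound 3 (0.81 log units; beyond the scatter), and replacing methoxy with hydrogen gives an at least 6.6-fold higher number from compound 1 to compound 3 (0.82 log units; beyond the scatter). The position therefore looked indifferent only while it carried a substituent, since compound 1 and compound 2 share a level that the unsubstituted anilino compound does not reach. Compound 3 has no number here, only a limit of the assay: the limit of > 64000 nM in this assay, at which 1 of the 3 values shown sits.

With only methyl and methoxy on one side and hydrogen on the other, the compounds shown leave open whether many groups at this place would hold the level of compound 1 and compound 2 or only these two, which a chlorine atom, a hydroxyl group or an ethyl group there could help to settle. They also leave open the full size of both new steps, as each is bounded on one side only.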